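The compounds below may be only part of what the source reports. "The series", "measured", "known", "first", "only" and "open" are said of these compounds alone.

Three compounds share one core and differ only in the group on the carbonyl carbon. Compound 1 `COc1cccc(-c2nc(SC)nc3sc(C(=O)N(C)C(C)(C)C)c(N)c23)c1` carries a methyl(tert-butyl)amino group there, and in a functional assay on HEK293 cells for agonist activity at Thyrotropin receptor (Homo sapiens), read by cAMP accumulation (on this read-out lower numbers stand for smaller maximal responses and higher numbers for larger maximal responses), compound 1 gives 3.6%. Compound 2 `COc1cccc(-c2nc(SC)nc3sc(C(=O)NCC#N)c(N)c23)c1` carries a (cyanomethyl)amino group, and in this assay compound 2 gives 3.6%. Compound 3 `COc1cccc(-c2nc(SC)nc3sc(C(=O)NCCO)c(N)c23)c1` carries a (2-hydroxyethyl)amino group, and in this assay compound 3 gives 2.9%. The three numbers lie within the usual scatter of one another: no change at the digits printed from compound 1 to compound 2 (within the scatter), a number 0.7 percentage points lower from compound 1 to compound 3 (within the scatter) and a number 0.7 percentage points lower from compound 2 to compound 3 (within the scatter). Compound 3 thus stands together with compound 1 and compound 2, and no order among the three can be read.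

Compound 4 `COc1cccc(-c2nc(SC)nc3sc(C(=O)NNC(C)(C)C)c(N)c23)c1` is the next step from compound 3: (tert-butyl)amino in place of 2-hydroxyethyl on an amide-type nitrogen. All three earlier steps changed the group on the carbonyl carbon, and none of them moved the response beyond the scatter, so compound 4 is expected to behave the same way, with a number 0.6 percentage points higher from compound 3 to compound 4 (within the scatter). The estimate for compound 4 in this assay is 3.5%, within a range from 0% to 12%.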

Compound 4, largest response reached (reported as efficacy), in percent of the reference or control that the assay uses: 6.4%
The estimate for compound 4 lay 2.9 percentage points below the measured number; measured number inside the range.
By their numbers in this assay, from the lowest: compounds 3, 1, 2 and 4 (each within the scatter of the next).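

In this assay, for the compounds shown here, (tert-butyl)amino in place of 2-hydroxyethyl on the amide-type nitrogen gives a number 3.5 percentage points higher from compound 3 to compound 4 (within the scatter) and, in place of cyanomethyl, gives a number 2.8 percentage points higher from compound 2 to compound 4 (within the scatter) while the response stays with the earlier compounds. Measured against the methyl(tert-butyl)amino group on the carbonyl carbon, ((tert-butyl)amino)amino gives a number 2.8 percentage points higher from compound 1 to compound 4 (within the scatter) and so extends the tolerated groups at this position to one with a nitrogen on the amide-type nitrogen, with no order among the four compounds. No measurement at hand bears on this result.

On these data alone, whether any group at this position can raise the response beyond the scatter remains open, for instance a carboxylic acid or a longer chain ending in an amine. Also open, as far as these compounds go, is how far the methoxy or methylthio groups of the shared core contribute to the response.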